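Halogen swap on the amide aryl ring

This account rests on a few compounds, and the source may have more. Where it says the series, first, only, none or still open, it means among the compounds named here.

Two analogues of the shared core have been run in a functional assay on MDA-MB-231 cells (Homo sapiens) for inhibition, read by MTT assay, with a stated time of 72 h; a higher number here means a weaker inhibitor, a lower number a stronger inhibitor. Compound 1 `O=C(CSc1nc(Nc2ccccc2)c2ccccc2n1)Nc1ccccc1F` gives > 50000 nM in this assay, which is a limit of the measurement and not a number. Compound 2 `O=C(CSc1nc(Nc2ccccc2)c2ccccc2n1)Nc1cccc(F)c1` gives > 50000 nM in this assay, again a limit. The step that the two limits leave unreadable from compound 1 to compound 2 therefore has no readable size. Across the series so far there is only (the limit of > 50000 nM in this assay, at which 2 of the 2 values shown sit).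

Compound 3 `O=C(CSc1nc(Nc2ccccc2)c2ccccc2n1)Nc1cccc(Br)c1` has not yet been measured. Its difference from compound 2 is bromo in place of fluoro on an aromatic carbon. Among the measured compounds shown here, no measured step covers a bromo for fluoro exchange on that ring; the single measured step concerns the fluorophenyl pattern and its size is hidden by the two limits. With compound 2 standing at the limit, the expectation for compound 3 in this assay is that it again returns the limit, or a number close to it, so the step that the limit leaves unreadable from compound 2 to compound 3 is expected to be small. The estimate for compound 3 in this assay is 60000 nM, spanning 15000 nM to 200000 nM.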

Compound 3, half-maximal inhibitory concentration: 17500 nM
Beside the measured number, compound 3's estimate is 3.4-fold (0.54 log units) above it, and the stated range covers the measured number.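

Bromo in place of fluoro on an aromatic carbon, meta to a large group, gives an at least 2.8-fold lower number from compound 2 to compound 3 (0.45 log units; beyond the scatter) in this assay, so this position on the amide aryl ring can respond to a change of halogen. The 3-bromophenyl group in place of 2-fluorophenyl gives an at least 2.8-fold lower number from compound 1 to compound 3 (0.45 log units; beyond the scatter), and both sizes are lower bounds, as one end of each step is a limit of the assay and not a number. Compound 3 gives the series its first readable number, while the step between the two fluorophenyl analogues still cannot be read: the limit of > 50000 nM in this assay, at which 2 of the 3 values shown sit.

The compounds shown leave open whether the drop in this assay is particular to bromo or would also follow from chloro, iodo, methyl or trifluoromethyl at the same place. They also leave open how a bromo group would read elsewhere on that ring, and whether an amine or a carboxylic acid there would keep a readable number.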